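This account rests on a few compounds, and the source may have more. Where it says the series, first, only, none or still open, it means among the compounds named here.

Measured so far in an ADME assay on PANC-1 cells (Homo sapiens) for inhibition, read by MTT assay, with a stated time of 48 h; a higher number here means a weaker inhibitor of growth, a lower number a stronger inhibitor of growth:
Compound 1 `O=[N+]([O-])c1ccc(Cn2cc(COc3ccccc3)nn2)cc1` gives > 100 ug/mL, a limit of the assay.
Compound 2 `Clc1ccc(Cn2cc(COc3ccc(Cl)cc3)nn2)cc1` gives > 100 ug/mL, a limit of the assay.
Compound 3 `Cc1cc(OCc2cn(Cc3ccc([N+](=O)[O-])cc3)nn2)ccc1Cl` gives > 100 ug/mL, a limit of the assay.

Compound 3 therefore stands only at a limit; the other two values shown are limits as well, and the limit of > 100 ug/mL in this assay, at which 3 of the 3 values shown sit, covers all three. Within the data shown here, the one step between measured compounds, a step that the two limits leave unreadable from compound 1 to compound 3, has no readable size because the limit of > 100 ug/mL in this assay, at which 3 of the 3 values shown sit, sets both of its ends. Compound 4 `Cc1cc(OCc2cn(Cc3ccc(Cl)cc3)nn2)ccc1Cl` differs from compound 3 by chloro in place of nitro on an aromatic carbon. Among the measured compounds shown here, no measured step bears directly on this change; compound 2 also carries chloro rather than nitro at that place and sits at its limit. The step that the limit leaves unreadable from compound 3 to compound 4 is thus expected to stay within the scatter, most likely as a further limit. Compound 4 is estimated at 150 ug/mL, within 60 ug/mL to 400 ug/mL.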

Compound 4, concentration for 50% growth inhibition: > 100 ug/mL
Compound 4: only a limit was reported; the forecaster's own chance of this, stated with the estimate: 80%; the middle value does not contradict the limit.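

Compound 4 stands at a limit of the assay, as do compound 2 and compound 3, so neither new step to compound 4 can be read: the limit of > 100 ug/mL in this assay, at which 4 of the 4 values shown sit. The compounds shown leave open whether any change on the shared core gives a measurable value in this assay.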